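A few compounds are considered here, and "the series" means these few. Any claim that something is new, unique, unknown or untested is made for them only; others in the source may bear on it.

- Compound 1 `c1ccc(-c2nc3cccnc3n2C2CCCC2)cc1`: 3000 nM
- Compound 2 `c1cnc2c(c1)nc(-c1cncnc1)n2C1CCCC1`: > 10000 nM

Both compounds were tested in a functional assay on MDA-MB-231 cells (Homo sapiens) for cytotoxicity, read by MTT assay, with a stated time of 24 h; on this read-out higher numbers stand for weaker inhibition and lower numbers for stronger inhibition. Compound 2 stands at > 10000 nM, which is a limit of this assay and not a number. Its true position is therefore unknown, and any step starting from it is uncertain in size.

The next compound, compound 3 `Cc1ccsc1-c1nc2cccnc2n1C1CCCC1`, has 3-methylthiophen-2-yl in place of pyrimidin-5-yl on an aromatic carbon. Going by the values given here, only one measured step bears on this change, and it involves the same position: an at least 3.3-fold higher number from compound 1 to compound 2 (0.52 log units; beyond the scatter). That step lies beyond the scatter, but it is a single comparison and it ends at a limit. Unlike pyrimidin-5-yl, the entering ring has no ring nitrogen, and in that respect it resembles the phenyl of compound 1, which gives 3000 nM. A move back towards that value is therefore expected, meaning a lower number, though thiophene and phenyl are not the same group. The expected change is an at least 2.5-fold lower number from compound 2 to compound 3 (0.39 log units; beyond the scatter). Compound 3 is estimated at 4000 nM, with an expected range from 1300 nM to 10000 nM.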

Compound 3, half-maximal inhibitory concentration: 138 nM
Beside the measured number, compound 3's estimate is 29-fold (1.46 log units) above it; the measured number lies below the stated range.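

Until now, this position, on an aromatic carbon between two ring nitrogen atoms, had shown only a loss, on going from phenyl to pyrimidin-5-yl. In this assay, the change to 3-methylthiophen-2-yl shows that the same position can also give a large gain, with a 22-fold lower number from compound 1 to compound 3 (1.34 log units; beyond the scatter), so the phenyl of compound 1 is not the best group seen here, and a change at this one place can move the number far in either direction. Against pyrimidin-5-yl the change reads as an at least 72-fold lower number from compound 2 to compound 3 (1.86 log units; beyond the scatter), but the true size of that step remains unknown because compound 2 sits at a limit and not at a number: the limit of > 10000 nM in this assay, at which 1 of the 3 values shown sits.

The entering group differs from phenyl in ring size, in its sulfur and in its methyl at the same time, so the compounds shown cannot say which of these features goes with the gain; a plain thiophen-2-yl or a methyl-bearing phenyl would separate them. Also open, on these data alone, is whether other groups at this position, such as an amine or a longer chain, would keep the gain, and the cyclopentyl group stays the same throughout.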